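The source may hold more compounds than are shown below. What is called first, only, known or untested is meant among the compounds shown, and "the series" means these compounds.

Working notes on the series, read in a functional assay (B cell) with Homo sapiens as the target; on this read-out higher numbers stand for weaker inhibition and lower numbers for stronger inhibition. Compound 1 `Nc1nc2c(c(=O)[nH]1)C[C@@H](CCc1ccc(C(=O)N[C@@H](C[C@H](F)C(=O)O)C(=O)O)cc1)CN2` gives 2930 nM, and compound 2 `C#CCN(Cc1ccc2nc(C)[nH]c(=O)c2c1)c1ccc(C(=O)N[C@@H](C[C@@H](F)C(=O)O)C(=O)O)cc1` gives 8.08 nM. Compound 2 therefore holds the lower of the two numbers, by a gap beyond the scatter. The two compounds differ in more than one place, so this gap says nothing about any single change.

Compound 3 `C#CCN(Cc1ccc2nc(C)[nH]c(=O)c2c1)c1ccc(C(=O)N[C@@H](C[C@H](F)C(=O)O)C(=O)O)cc1` is the next case: the two compounds have the same atoms and bonds and differ only in configuration as drawn: 1 of 2 stereo elements differ; a stereocentre at a saturated chain carbon is drawn R in compound 2 and S in compound 3. The atoms and bonds stay the same, and a stereocentre at a saturated chain carbon is drawn R in compound 2 and S in compound 3. Within the data shown here, no measured pair isolates a change of configuration, so the expectation is a judgement, with a small shift towards a higher number in this assay. The expected change is a 2.2-fold higher number from compound 2 to compound 3 (0.35 log units; beyond the scatter). For compound 3 the estimated value is 18 nM, with an expected range of 5 nM to 80 nM.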

Compound 3, half-maximal inhibitory concentration: 8.08 nM
The estimate for compound 3 lay 2.2-fold (0.35 log units) above the measured number; the measured number falls inside the stated range.
By their numbers in this assay, from the lowest: compounds 2 and 3 (each within the scatter of the next); then compound 1.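

In this assay, the change of drawn configuration at the saturated chain carbon gives no change at the digits printed from compound 2 to compound 3 (within the scatter). On the core of compound 2, this read-out therefore does not separate the R and S drawings at this stereocentre, and neither drawing can be called the better one. Unlike the gap between compound 1 and compound 2, which spans several changes at once, this result can be assigned to one place: the fact that compounds 2 and 3 differ only in the configuration as drawn

The compounds shown leave open whether the same insensitivity to configuration holds on the core of compound 1, or at the second stereocentre of the chain. They also leave open how the number would respond to a hydroxyl group or a chlorine atom in place of the fluorine on the chain.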